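Changing the Hexyl Chain of a Weak Inhibitor

The source may report more compounds than this note shows. Statements on the series, on what has been measured and on what is new or still open speak of the compounds shown alone.

Among the compounds with values here, in a functional assay on RAW264.7 cells (Mus musculus) for inhibition, read by Griess assay, with stated times of 1 h and 24 h (a lower number here means a stronger inhibitor, a higher number a weaker inhibitor), only one of the three compounds tested so far gives a number. Compound 1 `O=C1OC(Cc2nc(-c3ccccc3)no2)c2ccccc21` reaches only a limit of the assay, > 10000 nM. Compound 2 `COc1cc(OC)c2c(c1)C(C(O)c1ccc(O)cc1)OC2=O` also reaches only a limit, > 10000 nM. Within the data shown here, compound 3 `CCCCCCOc1ccc(C(O)C2OC(=O)c3c(OC)cc(OC)cc32)cc1`, which carries a hexyl chain, gives 5360 nM, the only true number available.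

Compound 4 `COCCCCOc1ccc(C(O)C2OC(=O)c3c(OC)cc(OC)cc32)cc1` changes that chain, with methoxy in place of ethyl on a saturated chain carbon, four bonds along the chain from an oxygen on an aromatic ring. Among the measured compounds shown here, one measured step bears on this, hexyl in place of hydrogen on an oxygen on an aromatic ring, which gave an at least 1.8-fold lower number from compound 2 to compound 3 (0.27 log units; that floor lies within the scatter). For the measured compounds named here, that step fixes no firm size, and no measured step tests a change within the chain. Only a small shift towards a weaker inhibitor is therefore expected, possibly none beyond the scatter, and the expected step is a 1.5-fold higher number from compound 3 to compound 4 (0.17 log units; within the scatter). Compound 4 is estimated at 8000 nM, with an expected range of 3500 nM to 18000 nM.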

Compound 4, half-maximal inhibitory concentration: 8210 nM
Compound 4: the middle estimate sits 1.0-fold (0.01 log units) below what was measured; the range from low to high includes it.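

In this assay, methoxy in place of ethyl on a saturated chain carbon, four bonds along the chain from an oxygen on an aromatic ring, gives a 1.5-fold higher number from compound 3 to compound 4 (0.19 log units; within the scatter), the only step shown that tests a change within the chain. The entering methoxy brings one hydrogen-bond acceptor that ethyl lacks, yet compound 3 and compound 4 cannot be told apart in this assay, so this place on the chain accepts that oxygen with no change beyond the scatter. Adding the whole chain gives an at least 1.2-fold lower number from compound 2 to compound 4 (0.08 log units; that floor lies within the scatter), which is only a floor because compound 2 stands at a limit of the assay: the limit of > 10000 nM in this assay, at which 2 of the 4 values shown sit.

The compounds shown leave open how an amine or a carboxylic acid at this place on the chain would read. They also leave open whether a longer chain would shift the number beyond the scatter.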